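Ester Chain Branching on the Naphthyl Thiourea

The source may hold more compounds than are shown below. What is called first, only, known or untested is meant among the compounds shown, and "the series" means these compounds.

Measured compounds and values in an assay on HEK-Blue hTLR2 cells for agonist activity at Toll-like receptor 2 (Homo sapiens), with a stated time of 24 h; on this read-out higher numbers stand for an effect only at larger amounts of compound and lower numbers for an effect already at smaller amounts:
compound 1 `CCOC(=O)c1c(N=C(S)Nc2ccc(F)cc2)sc2c1CCC2` gives 13300 nM
compound 2 `COC(=O)c1c(NC(=S)Nc2ccc(C(F)(F)F)cc2)sc2c1CCCC2` gives 33900 nM
compound 3 `CCCOC(=O)c1c(NC(=S)Nc2cccc3ccccc23)sc2c1CCC2` gives 820 nM

Of the compounds shown here, three have numbers in this assay so far. Compound 3 holds the lowest number of the three; compound 1 is the nearest to it, with a higher number, and compound 2 the furthest, also higher. Both gaps lie beyond the scatter, so compound 3 is the most potent of the measured set. For the measured compounds named here, the three differ from one another in more than one place at once, so no single structural step among the measured compounds can be read off, and none of them shows what a change at the ester chain alone does.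

Compound 4 `CC(C)COC(=O)c1c(NC(=S)Nc2cccc3ccccc23)sc2c1CCC2` differs from compound 3 in one place: methyl in place of hydrogen on a saturated chain carbon bound to two saturated chain carbons. The rest of the molecule, including the naphthyl thiourea, is kept. With no measured step of this kind in the set, the expected step of a 1.1-fold higher number from compound 3 to compound 4 (0.04 log units; within the scatter) is taken as small and within the scatter, with no direction assigned. Compound 4 is therefore expected to give about 900 nM, with a range from 300 nM to 2700 nM, in this assay.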

Compound 4, half-maximal effective concentration: 28200 nM
Compound 4: the middle estimate sits 31-fold (1.50 log units) below what was measured; measured number outside the range, above it.
By their numbers in this assay, from the lowest: compound 3; then compound 1; then compounds 4 and 2 (each within the scatter of the next).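

In this assay, the ester chain proves to be a position where a single added methyl matters: the change from propyl to isobutyl, methyl in place of hydrogen on a saturated chain carbon bound to two saturated chain carbons, gives a 34-fold higher number from compound 3 to compound 4 (1.54 log units; beyond the scatter). The earlier compounds shown here differ from one another in more than one place at once and could not isolate the ester chain; this first single-place step does so, with the naphthyl thiourea and the rest of the molecule kept, and shows that the number at this position is highly sensitive to branching. No available measurement bears on the reason for a step of this size.

From the compounds shown here alone, it remains open whether the step follows from the branch itself or from the added carbon, which a straight butyl ester on the same naphthyl thiourea would help separate. Also open, going by these compounds, are whether an isobutyl ester has a similar effect with the other thiourea groups of compound 1 and compound 2, and how a carboxylic acid or a primary amide in place of the ester would read in this assay.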